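Pyridin-2-yl to Pyrimidin-2-yl on the Amide-Type Nitrogen

The compounds below may be only part of what the source reports. "The series", "measured", "known", "first", "only" and "open" are said of these compounds alone.

Three measured compounds share one core and differ only in the group attached to the carbonyl carbon. Compound 1 `Cc1cc(C)cc(-c2c(O)nc3cc(Cl)c(NC(=O)c4cnccn4)cc3c2OCCC2CCCCN2)c1` carries pyrazin-2-yl there, and in a functional assay on cells (Pituitary gland cell) for antagonist activity at Gonadotropin-releasing hormone receptor (Rattus norvegicus) (on this read-out lower numbers stand for stronger inhibition and higher numbers for weaker inhibition), compound 1 gives 1.8 nM. Compound 2 `Cc1cc(C)cc(-c2c(O)nc3cc(Cl)c(NC(=O)Nc4cccnc4)cc3c2OCCC2CCCCN2)c1` carries (pyridin-3-yl)amino and gives 20 nM, while compound 3 `Cc1cc(C)cc(-c2c(O)nc3cc(Cl)c(NC(=O)Nc4ccccn4)cc3c2OCCC2CCCCN2)c1` carries (pyridin-2-yl)amino and gives 15 nM. Compound 3 therefore stands together with compound 2 and apart from compound 1: the step of an 8.3-fold higher number from compound 1 to compound 3 (0.92 log units; beyond the scatter) lies beyond the scatter, whereas a 1.3-fold lower number from compound 2 to compound 3 (0.12 log units; within the scatter) lies within it. Compound 4 `Cc1cc(C)cc(-c2c(O)nc3cc(Cl)c(NC(=O)Nc4ncccn4)cc3c2OCCC2CCCCN2)c1` differs from compound 3 by pyrimidin-2-yl in place of pyridin-2-yl on an amide-type nitrogen. For the measured compounds named here, no measured step makes this exact change. The closest guide is the shift of the ring nitrogen, a 1.3-fold lower number from compound 2 to compound 3 (0.12 log units; within the scatter), which left the number essentially unchanged; the large steps of an 11-fold higher number from compound 1 to compound 2 (1.05 log units; beyond the scatter) and an 8.3-fold higher number from compound 1 to compound 3 (0.92 log units; beyond the scatter) concern the link to the carbonyl carbon, which compound 4 keeps. The expected step is therefore no change at the digits printed from compound 3 to compound 4 (within the scatter), within the scatter. Compound 4 is estimated at 15 nM, with a range from 5 nM to 45 nM.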

Compound 4, half-maximal inhibitory concentration: 6 nM
Estimate against measurement, compound 4: 2.5-fold (0.40 log units) above; the range from low to high includes it.
By their numbers in this assay, from the lowest: compound 1; then compound 4; then compounds 3 and 2 (each within the scatter of the next).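

The ring on the amide-type nitrogen is not indifferent in this assay: a ring with 2 hetero atoms in place of 1 gives a 2.5-fold lower number from compound 3 to compound 4 (0.40 log units; beyond the scatter), even though the earlier shift of a single ring nitrogen had changed nothing beyond the scatter. The same ring also separates from the other pyridine isomer, with a 3.3-fold lower number from compound 2 to compound 4 (0.52 log units; beyond the scatter), so the number can move while the link to the carbonyl carbon stays the same. That link change is only partly made up, since a 3.3-fold higher number from compound 1 to compound 4 (0.52 log units; beyond the scatter) still remains.

The compounds shown offer no measured explanation for the gain from the second ring nitrogen. On these data alone, it also remains open whether pyrazin-2-yl on the same amide-type nitrogen, or a pyrimidin-2-yl ring carrying a methyl group or an amine, would bring the number closer to that of compound 1.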